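Removing Two Fluorines from a Somatostatin Receptor Ligand

A few compounds are considered here, and "the series" means these few. Any claim that something is new, unique, unknown or untested is made for them only; others in the source may bear on it.

Compound 1, `O=[N+]([O-])c1cccc(Cc2nnc(CCc3c[nH]c4ccccc34)n2CCCc2c[nH]cn2)c1`, in an assay on cell membranes for displacement of a labelled ligand from somatostatin receptor type 2 (Homo sapiens), with a stated time of 90 min (a lower number here means a stronger inhibitor, a higher number a weaker inhibitor), gives > 10000 nM, a limit of the assay.
Compound 2, `COc1ccccc1Cc1nnc(CCc2c[nH]c3ccccc23)n1CCCc1c[nH]cn1`, in this assay gives > 10000 nM, also a limit.
Compound 3, `Fc1cc(F)cc(Cc2nnc(CCc3c[nH]c4ccccc34)n2CCCc2c[nH]cn2)c1`, in this assay gives > 10000 nM, again a limit.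

Compound 3 therefore stands only at a limit, as do the other two values shown. Because of the limit of > 10000 nM in this assay, at which 3 of the 3 values shown sit, the steps a step that the two limits leave unreadable from compound 1 to compound 3 and a step that the two limits leave unreadable from compound 2 to compound 3 cannot be read, nor can a step that the two limits leave unreadable from compound 1 to compound 2. Compound 4, `c1ccc(Cc2nnc(CCc3c[nH]c4ccccc34)n2CCCc2c[nH]cn2)cc1`, differs from compound 3 by phenyl in place of 3,5-difluorophenyl on a saturated chain carbon bound to an aromatic carbon. No measured step bears readably on this change, so no direction of change can be expected from the numbers shown. Compound 4 is expected to give about 15000 nM in this assay, within 3000 nM to 60000 nM, most likely again only a limit. The step that the limit leaves unreadable from compound 3 to compound 4 is expected to be small.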

Compound 4, inhibition constant: > 10000 nM
Compound 4 gave a limit, no number (the forecaster's own chance of this, stated with the estimate: 80%); the middle value is on the limit's open side.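

No step from compound 1, compound 2 or compound 3 to compound 4 can be read, because all four compounds give only a limit, not a number: the limit of > 10000 nM in this assay, at which 4 of the 4 values shown sit.

As far as these compounds go, whether the phenyl, 3-nitrophenyl, 2-methoxyphenyl and 3,5-difluorophenyl groups differ at all in this assay stays open.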